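Ester for chloro in the diethylamino series

The source may report more compounds than this note shows. Statements on the series, on what has been measured and on what is new or still open speak of the compounds shown alone.

Values measured in a functional assay on Huh-7 cells (Homo sapiens) for antiproliferative activity, with a stated time of 48 h (a lower number here means a stronger inhibitor, a higher number a weaker inhibitor), are as follows.

- Compound 1 `COc1ccc(Nc2ccc(-c3ccccc3)nn2)cc1` gives 30000 nM in the assay
- Compound 2 `CCN(CC)c1ccc(-c2cccc(Cl)c2)nn1` gives > 25000 nM as a limit
- Compound 3 `CCN(CC)c1ccc(-c2ccc(C(=O)OC)cc2)nn1` gives 90 nM in the assay

Compound 2 stands at > 25000 nM as a limit and not a number. It therefore marks only the weak end of the series, and the size of any step away from it stays uncertain.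

Compound 4 `CCOC(=O)c1cccc(-c2ccc(N(CC)CC)nn2)c1` is reached from compound 2 by placing ethoxycarbonyl in place of chloro on an aromatic carbon, meta to a large group: ethoxycarbonyl in place of chloro on an aromatic carbon.

Going by the values given here, no measured pair isolates this change. Among the compounds with values here, the only guide is that compound 3 also carries an ester and gives 90 nM in this assay as a result. A clear gain in potency is therefore expected, well beyond the scatter, though a result at the limit remains possible.

The expected change is an at least 12-fold lower number from compound 2 to compound 4 (1.09 log units; beyond the scatter) as an estimate. The estimate for compound 4 is 2000 nM with an expected range of 200 nM to 25000 nM in this series.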

Compound 4, half-maximal inhibitory concentration: > 25000 nM
Compound 4: no number, only a limit; the forecaster's own chance of this, stated with the estimate: 30%; middle value at least 12-fold (1.09 log units) away from the limit.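

No step can be read between compound 2 and compound 4, as both stand as limits and not as numbers: the limit of > 25000 nM in this assay, at which 2 of the 4 values shown sit.

The compounds shown leave open whether ethoxycarbonyl in place of chloro changes antiproliferative activity at all, and by how much.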